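The compounds below may be only part of what the source reports. "The series", "measured", "known", "first", "only" and "open" are said of these compounds alone.

In an ADME assay on HUVEC cells (Homo sapiens) for cytotoxicity, read by MTT assay, with a stated time of 46 h (on this read-out lower numbers stand for stronger inhibition and higher numbers for weaker inhibition), compound 1 (`O=C1/C(=C\c2ccncc2)C(c2ccccc2)Oc2ccccc21`) gives 5410 nM and compound 2 (`O=C1/C(=C/c2ccc(Br)cc2)C(c2ccccc2)Oc2ccccc21`) gives 7230 nM so the two values sit within the usual scatter of each other. Compound 3 (`O=C1/C(=C\c2ccc(Br)cc2)C(c2ccccc2)Oc2ccccc21`) has the same atoms and bonds as compound 2 and differs by the two compounds have the same atoms and bonds; at least one stereo element is drawn with a configuration in one of them and without one in the other: 1 of 2 stereo elements differ; a double bond is drawn E in compound 2 and Z in compound 3 in that a double bond is drawn E in compound 2 and Z in compound 3. Going by the values given here, no measured pair shows such a change in this assay and so no step beyond the scatter is expected. The estimated 1.1-fold lower number from compound 2 to compound 3 (0.05 log units; within the scatter) stays within that scatter. For compound 3 the estimated value is 6500 nM with 2500 nM to 16000 nM as the expected range.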

Compound 3, half-maximal inhibitory concentration in the HUVEC assay: 29100 nM
Beside the measured number, compound 3's estimate is 4.5-fold (0.65 log units) below it; measured number above the stated range.
By their numbers in the HUVEC assay, from the lowest: compounds 1 and 2 (each within the scatter of the next); then compound 3.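

In the HUVEC assay, compound 2 gives 7230 nM and compound 3 gives 29100 nM, so the drawn geometry of the double bond proves to matter: with the same atoms and bonds, the step is a 4.0-fold higher number from compound 2 to compound 3 (0.60 log units; beyond the scatter). With the double bond drawn alike, 4-bromophenyl in place of pyridin-4-yl gives a 5.4-fold higher number from compound 1 to compound 3 (0.73 log units; beyond the scatter), so the close values of compounds 1 and 2 did not show that this group leaves the number unchanged. In a physicochemical assay for lipophilicity, read by HPLC (a higher number here means a more lipophilic compound, a lower number a more polar compound), compound 2 gives 4.46 and compound 3 gives 4.71. In the physicochemical assay the pair shows a number 0.25 log units higher from compound 2 to compound 3 (within the scatter), and the pair differs only in this: the fact that one of compounds 2 and 3 is drawn with a defined configuration and the other without, at the place where they differ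

From the compounds shown here alone, it remains open whether pyridin-4-yl shows the same geometry step with the double bond drawn as in compound 2. A carboxylic acid or an amine in place of the bromine also remains untested among the compounds shown.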